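Swapping the Oxygen Substituent on Compound 3

The source may hold more compounds than are shown below. What is called first, only, known or untested is meant among the compounds shown, and "the series" means these compounds.

Measured in a functional assay on DU-145 cells (Homo sapiens) for cytotoxicity, read by MTT assay; a higher number here means a weaker inhibitor, a lower number a stronger inhibitor
Compound 1 `CCCC(CC(=O)O[C@H](CC=C(C)C)C1=CC(=O)c2c(O)ccc(O)c2C1=O)OC(C)=O` gives 55700 nM
Compound 2 `CC(C)=CC[C@@H](OC(=O)C1CCCO1)C1=CC(=O)c2c(O)ccc(O)c2C1=O` gives 10500 nM
Compound 3 `CC(C)=CC[C@@H](OCCO)C1=CC(=O)c2c(O)ccc(O)c2C1=O` gives 9900 nM

Compound 3 cannot be told apart from compound 2, with a 1.1-fold lower number from compound 2 to compound 3 (0.03 log units; within the scatter), and both carry lower numbers than compound 1. Compound 4 `CC(C)=CC[C@@H](OC(=O)c1ccoc1)C1=CC(=O)c2c(O)ccc(O)c2C1=O` has (furan-3-yl)carbonyl in place of 2-hydroxyethyl on an oxygen on a saturated carbon. Within the data shown here, two steps bear on this. Exchanging (oxolan-2-yl)carbonyl for 2-hydroxyethyl at that oxygen gave a 1.1-fold lower number from compound 2 to compound 3 (0.03 log units; within the scatter). Changing the group on the carbonyl carbon, oxolan-2-yl for 2-acetoxypentyl, gave a 5.3-fold lower number from compound 1 to compound 2 (0.72 log units; beyond the scatter), so a change of that kind can matter. Even so, no step beyond the scatter is expected in this assay. The estimated step is a 1.0-fold higher number from compound 3 to compound 4 (0.00 log units; within the scatter). The estimated value for compound 4 is 10000 nM, within an expected range of 4000 nM to 25000 nM.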

Compound 4, half-maximal inhibitory concentration: > 100000 nM
Compound 4 gave a limit, no number; the forecaster's own chance of this, stated with the estimate: 3%; at least 10-fold (1.00 log units) between middle value and limit.
By their numbers in this assay, from the lowest: compounds 3 and 2 (each within the scatter of the next); then compound 1. At a limit, above all of these: compound 4.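

Compound 4 stands at a limit of the assay, not a number: the limit of > 100000 nM in this assay, at which 1 of the 4 values shown sits.

This oxygen substituent is not indifferent, although compound 2 and compound 3 alone suggested that it was: (furan-3-yl)carbonyl in place of 2-hydroxyethyl on an oxygen on a saturated carbon gives an at least 10-fold higher number from compound 3 to compound 4 (1.00 log units; beyond the scatter), and furan-3-yl in place of oxolan-2-yl on the carbonyl carbon gives an at least 9.5-fold higher number from compound 2 to compound 4 (0.97 log units; beyond the scatter). Furan-3-yl in place of 2-acetoxypentyl on the carbonyl carbon gives an at least 1.7-fold higher number from compound 1 to compound 4 (0.25 log units; that floor lies within the scatter), and with that floor within the scatter, this step leaves the size of the difference open.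

Whether the five-membered aromatic ring itself accounts for this remains open. So does how a benzoyl group, or an amine on the 2-hydroxyethyl chain, would fare at this oxygen in this assay.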